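Aryl Swap on the Shared Core: Little Shift Expected

The source may report more compounds than this note shows. Statements on the series, on what has been measured and on what is new or still open speak of the compounds shown alone.

Compound 1 `CC(C)Cc1csc(N)c1C(=O)c1ccc(Cl)cc1`, compound 2 `CC(C)(C)Cc1c(-c2ccc(F)cc2)sc(N)c1C(=O)c1ccc(Cl)cc1` and compound 3 `Cc1ccc(C(=O)c2c(CC(C)(C)C)csc2N)cc1` share one core and differ only in their outer groups. In an assay on CHO cells for displacement of a labelled ligand from adenosine receptor A1 (Homo sapiens), read by scintillation counting, tested at 10 uM (on this read-out higher numbers stand for more inhibition at the one concentration tested (going by the name of the read-out) and lower numbers for less inhibition), compound 1 gives 1%, compound 2 gives 1% and compound 3 gives 1%; the three lie level within the usual scatter, so compound 2 stands with the others rather than apart from them. Compound 4 `CC(C)(C)Cc1c(-c2ccsc2)sc(N)c1C(=O)c1ccc(Cl)cc1` differs from compound 2 by a single change: thiophen-3-yl in place of 4-fluorophenyl on an aromatic carbon. Within the data shown here, no measured pair shows what such a swap does here, so the only guide is that every compound so far sits near the floor of this assay. The step of a number 2 percentage points higher from compound 2 to compound 4 (within the scatter) is therefore expected to be none beyond the scatter. Compound 4 is estimated at 3%, with a range from 0% to 15%.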

Compound 4, a percentage reported as inhibition, at one concentration (the size of the read-out at that concentration, not a potency): 2%
Compound 4: the middle estimate sits 1 percentage points above what was measured; the measured number falls inside the stated range.
By their numbers in this assay, from the lowest: compounds 1, 2, 3 and 4 (each within the scatter of the next).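

Thiophen-3-yl can replace 4-fluorophenyl on this aromatic carbon next to the ring sulfur, and the swap gives a number 1 percentage points higher from compound 2 to compound 4 (within the scatter) in this assay. So a smaller aromatic ring carrying a sulfur leaves the read-out where the larger 4-fluorophenyl ring had it, and both compounds remain close to the bottom of the scale. Nothing measured here gives a reason for this result. Still open, going by these compounds, is whether an amine or a carboxylic acid on this carbon, or a longer chain in place of the neopentyl group, would raise the inhibition at all.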